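Anilide substituent series: the hydroxy-to-acetyl step

The source may report more compounds than this note shows. Statements on the series, on what has been measured and on what is new or still open speak of the compounds shown alone.

Three analogues of the shared core differ only in the group on the anilide ring. Compound 1 `Cc1ccc(NC(=O)CSC(=S)N[C@H]2CCOC2=O)cc1` carries methyl there, and in a functional assay on SMMC-7721 cells (Homo sapiens) for cytotoxicity, read by MTT assay, with a stated time of 72 h (on this read-out higher numbers stand for weaker inhibition and lower numbers for stronger inhibition), compound 1 gives 32700 nM. Compound 2 `O=C(CSC(=S)N[C@H]1CCOC1=O)Nc1ccc(F)cc1` carries fluoro. In this assay compound 2 returns only a limit, > 128000 nM. Compound 3 `O=C(CSC(=S)N[C@H]1CCOC1=O)Nc1ccc(O)cc1` carries hydroxy. In this assay compound 3 likewise returns only a limit, > 128000 nM. Compound 3 thus stands at the limit of > 128000 nM in this assay, at which 2 of the 3 values shown sit, with no readable number of its own. The measured steps are an at least 3.9-fold higher number from compound 1 to compound 2 (0.59 log units; beyond the scatter) and an at least 3.9-fold higher number from compound 1 to compound 3 (0.59 log units; beyond the scatter), while a step that the two limits leave unreadable from compound 2 to compound 3.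

Compound 4 `CC(=O)c1ccc(NC(=O)CSC(=S)N[C@H]2CCOC2=O)cc1` is the next member; it differs from compound 3 in acetyl in place of hydroxy on an aromatic carbon. Within the data shown here, no measured step brings in acetyl, so only the comparison of hydroxy against methyl offers any bearing. Among the measured compounds shown here, compound 1 with methyl is the one member with a readable number, 32700 nM. Compound 3 with hydroxy gives only a limit. Acetyl has no precedent in this set, so the step is expected to be an at least 1.8-fold lower number from compound 3 to compound 4 (0.26 log units; that floor lies within the scatter), with its direction not readable from what is shown. A fair chance remains that compound 4 again returns only a limit. On that basis compound 4 is estimated at 70000 nM, with a range from 20000 nM to 250000 nM.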

Compound 4, half-maximal inhibitory concentration: > 128000 nM
Compound 4 was reported as a limit (the forecaster's own chance of this, stated with the estimate: 55%); middle value at least 1.8-fold (0.26 log units) away from the limit.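

Acetyl, with 3 heavy atoms and 0 hydrogen-bond donors, gives no readable number at this position on the anilide ring any more than hydroxy or fluoro does, so the limit now covers groups that differ in size and in donor count in this assay: the limit of > 128000 nM in this assay, at which 3 of the 4 values shown sit. Methyl remains the only group shown with a readable number, and the one step to acetyl that can be read is an at least 3.9-fold higher number from compound 1 to compound 4 (0.59 log units; beyond the scatter). The steps from compound 2 and from compound 3 to compound 4 cannot be read, as both ends of each are limits, so no order among fluoro, hydroxy and acetyl can be drawn.

From the compounds shown here alone, it remains open whether the readable number belongs to methyl alone or extends to ethyl or a longer alkyl chain, and whether chloro, an amine or a carboxylic acid on the same aromatic carbon would also give a readable number. Also open, going by these compounds, is how far compound 2, compound 3 and compound 4 lie from compound 1, as each of these steps has only a lower bound.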